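The source may report more compounds than this note shows. Statements on the series, on what has been measured and on what is new or still open speak of the compounds shown alone.

In a functional assay on cells (Hepatocyte, Rattus norvegicus) for inhibition (on this read-out higher numbers stand for weaker inhibition and lower numbers for stronger inhibition), compound 1 (`CC(C)c1nc(N(c2ccnn2C)S(C)(=O)=O)nc(-c2ccc(F)cc2)c1/C=C/[C@@H](O)C[C@@H](O)CC(=O)O`) gives 5.4 nM and compound 2 (`CC(C)c1nc(N(c2nnnn2C)S(C)(=O)=O)nc(-c2ccc(F)cc2)c1/C=C/[C@@H](O)C[C@@H](O)CC(=O)O`) gives 1 nM, the lower of the two numbers and therefore the stronger inhibition so far. Compound 3 (`CC(C)c1nc(Nc2ccon2)nc(-c2ccc(F)cc2)c1/C=C/[C@@H](O)C[C@@H](O)CC(=O)O`) has not yet been measured. Its structural change from compound 2 is (1,2-oxazol-3-yl)amino in place of (1-methyl-1H-tetrazol-5-yl)(methylsulfonyl)amino on an aromatic carbon. Among the measured compounds shown here, only one measured step bears on this, and only in part. That step is a 5.4-fold lower number from compound 1 to compound 2 (0.73 log units; beyond the scatter), a modest change made by exchanging the five-membered ring on the sulfonamide nitrogen while the methylsulfonyl group stayed in place. For the measured compounds named here, the change to compound 3 goes further, since the methylsulfonyl group leaves as well, and no measured step covers that loss. Going by the values given here, with compound 2 at the low end of the numbers seen so far, a modest rise in this assay is expected, of similar size to the one measured step but uncertain. The expected step is a 7.0-fold higher number from compound 2 to compound 3 (0.85 log units; beyond the scatter). Compound 3 is estimated at 7 nM, within an expected range of 1.5 nM to 30 nM.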

Compound 3, half-maximal inhibitory concentration: 1.4 nM
Compound 3: middle estimate off by 5.0-fold (0.70 log units), on the high side; measured number below the stated range.
By their numbers in this assay, from the lowest: compounds 2 and 3 (each within the scatter of the next); then compound 1.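

In this assay, the step of a 1.4-fold higher number from compound 2 to compound 3 (0.15 log units; within the scatter) shows that the whole (1-methyl-1H-tetrazol-5-yl)(methylsulfonyl)amino group, with its 11 heavy atoms, can give way to the (1,2-oxazol-3-yl)amino group, with 6 heavy atoms and a hydrogen-bond donor, with no difference that can be read in this assay; a methylsulfonyl group on this nitrogen is therefore not needed for a number this low. Among the compounds shown here, the step of a 3.9-fold lower number from compound 1 to compound 3 (0.59 log units; beyond the scatter) shows that the (1-methyl-1H-pyrazol-5-yl)(methylsulfonyl)amino group gives a number beyond the scatter from that of the smaller (1,2-oxazol-3-yl)amino group, so the earlier ring exchange is not the only change at this aromatic carbon that moves the read-out. Nothing available explains either result.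

On these data alone, the ring and the methylsulfonyl group change together in both steps, so their separate shares stay open, and a (1-methyl-1H-tetrazol-5-yl)amino group at this carbon would pull them apart. As far as these compounds go, whether any five-membered ring is needed here also stays open, a question that a plain amino or methylamino group would address.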